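The compounds below may be only part of what the source reports. "The series", "measured", "known", "first", "only" and "open" are said of these compounds alone.

Compound 1, `CC#C[C@@H](CC(=O)O)c1ccc(OC[C@H]2COc3ccc(Cl)cc3O2)cc1`, gives 86% in a functional assay on HEK293 cells for agonist activity at Free fatty acid receptor 1 (Homo sapiens), read by fluorescence and calcium flux, with a stated time of 10 min; a higher number here means a larger maximal response, a lower number a smaller maximal response.
Compound 2, `CC#C[C@@H](CC(=O)O)c1ccc(OC[C@H]2COc3ccc(F)cc3O2)cc1`, gives 86%.
Compound 3, `CC#C[C@@H](CC(=O)O)c1ccc(OC[C@H]2COc3ccc(OC(F)(F)F)cc3O2)cc1`, gives 73%.

Compound 3 stands lowest of the three numbers, and its gap to compound 1 and to compound 2 lies beyond the scatter. Compound 4, `CC#C[C@@H](CC(=O)O)c1ccc(OC[C@H]2COc3ccc(C(=O)N(C)C)cc3O2)cc1`, differs from compound 3 by dimethylcarbamoyl in place of trifluoromethoxy on an aromatic carbon. Going by the values given here, no measured step involves dimethylcarbamoyl, so the only guidance comes from the same position: a number 13 percentage points lower from compound 1 to compound 3 (beyond the scatter) and a number 13 percentage points lower from compound 2 to compound 3 (beyond the scatter), both modest, while no change at the digits printed from compound 1 to compound 2 (within the scatter). Replacing the trifluoromethoxy group that accompanied the lower number is therefore expected to move this assay upward by a modest step at most, with wide uncertainty. Compound 4 is expected at 78%, between 63% and 93%, which corresponds to an estimated a number 5 percentage points higher from compound 3 to compound 4 (within the scatter).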

Compound 4, largest response reached (Emax), in percent of the reference or control that the assay uses: 32%
Compound 4: middle estimate off by 46 percentage points, on the high side, and the stated range ends above it.
By their numbers in this assay, from the lowest: compound 4; then compound 3; then compounds 1 and 2 (each within the scatter of the next).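

Sites on this aromatic carbon are not interchangeable at equal size in this assay: dimethylcarbamoyl and trifluoromethoxy carry the same heavy-atom count, yet the change gives a number 41 percentage points lower from compound 3 to compound 4 (beyond the scatter) as its result. The fall is greater against the halogens, with a number 54 percentage points lower from compound 2 to compound 4 (beyond the scatter) and a number 54 percentage points lower from compound 1 to compound 4 (beyond the scatter) as the steps, so this place tolerates far less than the earlier modest drop suggested. Nothing available accounts for this loss.
As far as these compounds go, whether it follows from the carbonyl or from the two methyl groups on nitrogen stays open. A primary carboxamide or a nitrile at the same place would help separate these.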